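The compounds below may be only part of what the source reports. "The series", "measured", "known", "first", "only" and "open" are said of these compounds alone.

In a functional assay on HL-60 cells (Homo sapiens) for cytotoxicity, read by ELISA, with a stated time of 2 days (on this read-out higher numbers stand for weaker inhibition and lower numbers for stronger inhibition), compound 1 `Oc1ccccc1-c1cc(-c2ccccc2)cc(-c2ccccc2O)n1` gives 22400 nM and compound 2 `Oc1cccc(-c2cc(-c3ccccc3)nc(-c3ccccc3)c2)c1` gives 13500 nM as its half-maximal inhibitory concentration. These two numbers lie within the scatter of each other, so compound 2 stands level with compound 1 on the evidence so far, and they cannot be told apart in this read-out. Compound 3 `Oc1cccc(-c2cc(-c3ccccc3)nc(-c3ccccn3)c2)c1` has not yet been measured. It differs from compound 2 in one place, with pyridin-2-yl in place of phenyl on an aromatic carbon, next to the ring nitrogen: pyridin-2-yl in place of phenyl on an aromatic carbon. No measured pair among these compounds shows what this exchange does, so the data offer no direct guide to its size. The expectation therefore starts from compound 2 at 13500 nM and foresees no step beyond the scatter in this assay, in either direction. The estimated step, a 1.1-fold lower number from compound 2 to compound 3 (0.05 log units; within the scatter), is expected to stay small. Compound 3 is expected at 12000 nM, within an estimated range of 4500 nM to 32000 nM.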

Compound 3, half-maximal inhibitory concentration: 15100 nM
For compound 3 the middle estimate is 1.3-fold (0.10 log units) below the measured one; the range from low to high includes it.
By their numbers in this assay, from the lowest: compounds 2, 3 and 1 (each within the scatter of the next).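

In this assay, for the compounds shown here, the exchange of phenyl for pyridin-2-yl on the aromatic carbon next to the ring nitrogen comes to a 1.1-fold higher number from compound 2 to compound 3 (0.05 log units; within the scatter), and this is the first reading of a single exchange, since compound 1 and compound 2 differ in more than one place. It shows that, at this position, a six-membered aromatic ring with one hetero atom and one hydrogen-bond acceptor stands level with the all-carbon ring of the same heavy-atom count, so the ring nitrogen of pyridin-2-yl makes no difference that this read-out can resolve. Nothing measured here offers an explanation for the size of this step.

On these data alone, the two groups compared are both six-membered aromatic rings, so it remains open whether pyridin-3-yl, pyridin-4-yl or a group of another kind, such as an amine, a carboxylic acid or a longer alkyl chain, on this carbon would move the number beyond the scatter. As far as these compounds go, it also remains open whether pyridin-2-yl would stand level with phenyl in the same way if the 3-hydroxyphenyl group of compound 3 were replaced by another group.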